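Sulfonamide series: cytotoxicity outlook for compound 4

The source may report more compounds than this note shows. Statements on the series, on what has been measured and on what is new or still open speak of the compounds shown alone.

Measured compounds:
compound 1 `Cc1cccc(S(=O)(=O)Nc2ccc(-c3nc4ccccc4o3)cc2)c1` gives > 100000 nM
compound 2 `O=S(=O)(Nc1ccc2oc(-c3ccccc3)nc2c1)c1cccs1` gives 97000 nM
compound 3 `COc1ccccc1S(=O)(=O)Nc1ccc2oc(-c3ccccc3)nc2c1` gives 41000 nM

In an ADME assay on HEK293 cells (Homo sapiens) for cytotoxicity, read by resazurin assay, with a stated time of 48 h (on this read-out higher numbers stand for lower toxicity in this test and lower numbers for higher toxicity in this test), compound 1 gives > 100000 nM, which is a limit of the measurement and not a number. Compound 1 thus sits at the limit of > 100000 nM in this assay, at which 1 of the 3 values shown sits, so its position relative to compound 2 and compound 3 cannot be fixed more closely than that. Compound 4 `O=S(=O)(Nc1ccc(-c2nc3ccccc3o2)cc1)c1ccc(Cl)c(Cl)c1` differs from compound 1 by 3,4-dichlorophenyl in place of 3-methylphenyl on a sulfonyl sulfur. Going by the values given here, the single measured step, a 2.4-fold lower number from compound 2 to compound 3 (0.37 log units; beyond the scatter), concerns a different exchange on the sulfonyl sulfur, set on a different arrangement of the shared core, and was modest in size; no measured step covers the exchange between compound 1 and compound 4. On that basis a step of at most modest size is expected in this assay, with no clear direction. Compound 4 is therefore expected to give an estimated 90000 nM, with a range of 35000 nM to 200000 nM, which means an expected step of an at least 1.1-fold lower number from compound 1 to compound 4 (0.04 log units; that floor lies within the scatter) that need not exceed the scatter.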

Compound 4, half-maximal cytotoxic concentration: > 100000 nM
Compound 4: a limit, no number (the forecaster's own chance of this, stated with the estimate: 45%); at least 1.1-fold (0.04 log units) between middle value and limit.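

In this assay compound 4 gives > 100000 nM, which is a limit and not a number. Going by these compounds alone, compound 1 also stands at a limit, so no step between compound 1 and compound 4 can be read. The compounds shown leave open how 3,4-dichlorophenyl and 3-methylphenyl on a sulfonyl sulfur compare on this read-out.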